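The source may hold more compounds than are shown below. What is called first, only, known or untested is meant among the compounds shown, and "the series" means these compounds.

Working notes on the amidine series. Compound 1 `CC(C)N(C1=NCCN1)c1c(Br)cccc1Br` gives 11.2 in a physicochemical assay for acid dissociation, level with compound 3 `Brc1cccc(Br)c1N(C1=NCCN1)C1CCCC1` at the digits shown, the two together the highest of the three measured numbers; compound 3 gives 11.2. Compound 2 `CC(C)=CCN(C1=NCCN1)c1c(Br)cccc1Br` is the furthest from compound 1; in this assay compound 2 gives 10.8.

Step to compound 4 `Brc1cccc(Br)c1N(Cc1cccs1)C1=NCCN1`: (thiophen-2-yl)methyl in place of isopropyl on a nitrogen on an aromatic ring. For the measured compounds named here, two measured steps bear on it, both exchanges of the isopropyl at the same nitrogen. The step of no change at the digits printed from compound 1 to compound 3 (within the scatter) shows that a saturated ring in that position leaves the read-out unchanged. The step of a number 0.40 log units lower from compound 1 to compound 2 (beyond the scatter) shows that an unsaturated group in that position lowers it, and the step of a number 0.40 log units higher from compound 2 to compound 3 (beyond the scatter) shows the same gap from the other side. The (thiophen-2-yl)methyl group carries an aromatic ring and is the largest group placed at this nitrogen so far, so nothing measured covers it exactly; the change from compound 1 to compound 2 is the closer precedent, and a lowering of similar or somewhat greater size is expected, a number 0.60 log units lower from compound 1 to compound 4 (beyond the scatter). Compound 4 is therefore estimated at 10.6, with a range of 10.1 to 11, as no measured change at this nitrogen has moved the number more than the step to compound 2.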

Compound 4, acid dissociation constant: 10.5
For compound 4 the middle estimate is 0.10 log units above the measured one; the measured number falls inside the stated range.
By their numbers in this assay, from the lowest: compounds 4 and 2 (each within the scatter of the next); then compounds 1 and 3 (each within the scatter of the next).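

In this assay the (thiophen-2-yl)methyl exchange gives a number 0.70 log units lower from compound 1 to compound 4 (beyond the scatter) and a number 0.70 log units lower from compound 3 to compound 4 (beyond the scatter), so a second group on this nitrogen stands apart from both isopropyl and cyclopentyl, where earlier compound 2 stood alone. Thiophen-2-yl in place of 2-methylprop-1-en-1-yl on the saturated chain carbon gives a number 0.30 log units lower from compound 2 to compound 4 (within the scatter), so compound 2 and compound 4 cannot be ordered, and the four compounds fall into two sets: compound 2 and compound 4, each with a double bond or aromatic ring on that chain carbon, and compound 1 and compound 3, with neither, and no compound goes against this split. Nothing on hand gives a reason for the split.

The saturated chain carbon on the nitrogen and the unsaturation beyond it occur together in compound 2 and compound 4, so the two remain unseparated, and a cyclopentylmethyl or butyl group at this nitrogen would pull them apart. On these data alone, whether a phenylmethyl group or a chain ending in an amine would read with compound 2 and compound 4 also remains open.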